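The source may report more compounds than this note shows. Statements on the series, on what has been measured and on what is new or still open speak of the compounds shown alone.

Measured so far in a functional assay (cardiac atrium) for agonist activity, with Cavia porcellus as the target; on this read-out lower numbers stand for an effect already at smaller amounts and higher numbers for an effect only at larger amounts of compound:

compound 1, `CC1=C(C(=O)O[C@H](C)CO[N+](=O)[O-])[C@H](c2cccc3nonc23)C([N+](=O)[O-])=C(C)C1`, gives 1920 nM
compound 2, `CC1=C(C(=O)OCCCCO[N+](=O)[O-])C(c2cccc3nonc23)C([N+](=O)[O-])=C(C)C1`, gives 4030 nM
compound 3, `CC1=C(C(=O)OC(C)CO[N+](=O)[O-])C(c2cccc3nonc23)C([N+](=O)[O-])=C(C)C1`, gives 1860 nM
compound 4, `CC1=C(C(=O)OCCCO[N+](=O)[O-])C(c2cccc3nonc23)C([N+](=O)[O-])=C(C)C1`, has not yet been measured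

Of the three numbers, compound 2 stands highest, and the nearest of the other two is compound 1. All three compounds share the same core and differ only in the chain that carries the nitrooxy group on the ester oxygen.

The move to compound 4 shortens that chain by one carbon: nitrooxy in place of (nitrooxy)methyl on a saturated chain carbon, three bonds along the chain from an oxygen next to a carbonyl group. Two measured steps can be set beside it. The step of a 2.2-fold lower number from compound 2 to compound 3 (0.34 log units; beyond the scatter) also takes one carbon out of the chain, though there the carbon is moved into a branch rather than simply removed, and it brought a modest drop. The step of a 1.0-fold lower number from compound 1 to compound 3 (0.01 log units; within the scatter) concerns only whether the stereocentres are drawn with a configuration, as the fact that one of compounds 1 and 3 is drawn with a defined configuration and the other without, at the place where they differ shows, so it says nothing about the chain length.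

On this basis a modest lowering of the number is expected for compound 4, a 1.7-fold lower number from compound 2 to compound 4 (0.23 log units; within the scatter), of about the size seen from compound 2 to compound 3. Compound 4 is therefore estimated at 2400 nM in this assay, with a likely range from 1200 nM to 5000 nM.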

Compound 4, half-maximal effective concentration: 52300 nM
Compound 4: the middle estimate sits 22-fold (1.34 log units) below what was measured; the measured number lies above the stated range.
By their numbers in this assay, from the lowest: compounds 3 and 1 (each within the scatter of the next); then compound 2; then compound 4.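

In this assay, within the data shown here, shortening 4-(nitrooxy)butyl to 3-(nitrooxy)propyl gives a 13-fold higher number from compound 2 to compound 4 (1.11 log units; beyond the scatter) and so shows that this chain is far from indifferent to the loss of a single carbon, a sensitivity that the modest differences among the earlier compounds did not reveal. The branched and straight groups on the oxygen next to the carbonyl group match in their counts of carbon, nitrogen and oxygen atoms, yet the change gives a 28-fold higher number from compound 3 to compound 4 (1.45 log units; beyond the scatter) and shows that, among these compounds, the arrangement of the chain matters as well as its atom count. The one available observation concerns only how stereo elements are drawn, so it offers no explanation for either large step.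

The compounds shown leave open how the number changes with a shorter chain such as 2-(nitrooxy)ethyl or a longer one such as 5-(nitrooxy)pentyl, and so whether the 3-(nitrooxy)propyl result is an isolated drop or part of a wider trend. They also leave open what a hydroxyl group in place of the nitrooxy group would do on the same chains, and whether a methyl branch would have the same effect at other chain carbons.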